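Swapping Fluoro for Iodo, a Change Made Twice

A few compounds are considered here, and "the series" means these few. Any claim that something is new, unique, unknown or untested is made for them only; others in the source may bear on it.

Compound 1 `O=C1C(=O)N(CCCCCn2cc(COc3cc(=O)oc4ccccc34)nn2)c2ccc(F)cc21` gives 59% in a functional assay on HCT-116 cells (Homo sapiens) for inhibition, read by sulforhodamine B assay, with a stated time of 48 h, tested at 50 uM; a higher number here means more inhibition of growth at the concentration tested, a lower number less inhibition of growth.
Compound 2 `O=C1C(=O)N(CCCCCn2cc(COc3cc(=O)oc4ccccc34)nn2)c2ccc(I)cc21` gives 36% in this assay.
Compound 3 `O=C1C(=O)N(CCCCn2cc(COc3cc(=O)oc4ccccc34)nn2)c2ccc(F)cc21` gives 67% in this assay.

Compound 2 differs from compound 1 in one place: iodo in place of fluoro on an aromatic carbon. That change brought a number 23 percentage points lower from compound 1 to compound 2 (beyond the scatter). Compound 3 and compound 1 differ in more than one place, and the difference between the two cores is not broken down here; their two values lie within the usual scatter of each other.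

Compound 4 `O=C1C(=O)N(CCCCn2cc(COc3cc(=O)oc4ccccc34)nn2)c2ccc(I)cc21` is not yet measured. It differs from compound 3 exactly as compound 2 differs from compound 1: iodo in place of fluoro on an aromatic carbon. The same change at the same place is therefore tested a second time. Because the first instance gave a number 23 percentage points lower from compound 1 to compound 2 (beyond the scatter), a step of similar size is expected, and compound 4 is estimated to show a number 23 percentage points lower from compound 3 to compound 4 (beyond the scatter). On that basis compound 4 is expected to give about 44% in this assay, likely between 30% and 58%.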

Compound 4, percent growth inhibition at one concentration: 57%
Estimate against measurement, compound 4: 13 percentage points below; the measured number falls inside the stated range.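

On the core of compound 3, iodo in place of fluoro brought a number 10 percentage points lower from compound 3 to compound 4 (within the scatter) in this assay. Set beside the first case, the two steps cannot be told apart: the same change on two cores in this assay, a number 23 percentage points lower (beyond the scatter) from compound 1 to compound 2 and a number 10 percentage points lower (within the scatter) from compound 3 to compound 4, 13 percentage points apart, within the scatter of two such steps. This fits a change that carries over between the two cores, but it does not prove that it does, since the second step on its own cannot be told from no change and two pairs make no general rule.

The compounds shown leave open how chloro or bromo would read on the same aromatic carbon. They also leave open whether an amine or a carboxylic acid there, or a longer chain, would alter the picture.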